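The source may report more compounds than this note shows. Statements on the series, on what has been measured and on what is new or still open speak of the compounds shown alone.

Compound 1 `O=C(O)CCCSCCN1C(=O)SC[C@@H]1/C=C/[C@@H](O)Cc1ccccc1`: 56 mL/min/kg
Compound 2 `COCc1cccc(C[C@H](O)/C=C/[C@H]2CSC(=O)N2CCSCCCC(=O)O)c1`: 47 mL/min/kg

Both compounds were measured in an in vivo ADME assay on the whole organism for pharmacokinetics, with Rattus norvegicus as the target; a lower number here means slower removal, a higher number faster removal of the compound. The two numbers lie within the usual scatter of each other: a 1.2-fold lower number from compound 1 to compound 2 (0.08 log units; within the scatter). Compound 3 `O=C(O)CCCSCCN1C(=O)SC[C@@H]1/C=C/[C@@H](O)Cc1cccc(C(F)(F)F)c1` has not yet been measured; it differs from compound 2 by trifluoromethyl in place of methoxymethyl on an aromatic carbon. For the measured compounds named here, the only measured step that bears on this change is the one from compound 1 to compound 2, and it stayed within the scatter. Going by the values given here, no measured step covers the entering trifluoromethyl. The expected step is a 1.1-fold higher number from compound 2 to compound 3 (0.03 log units; within the scatter), nothing beyond the scatter. Compound 3 is therefore estimated at 50 mL/min/kg, between 30 mL/min/kg and 85 mL/min/kg.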

Compound 3, clearance: 51 mL/min/kg
Beside the measured number, compound 3's estimate is 1.0-fold (0.01 log units) below it; the range from low to high includes it.
By their numbers in this assay, from the lowest: compounds 2, 3 and 1 (each within the scatter of the next).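

In this assay, trifluoromethyl in place of methoxymethyl on this aromatic carbon gives a 1.1-fold higher number from compound 2 to compound 3 (0.04 log units; within the scatter), so two differently built groups now read alike here. Trifluoromethyl in place of hydrogen on the same carbon gives a 1.1-fold lower number from compound 1 to compound 3 (0.04 log units; within the scatter), so neither group stands apart from hydrogen at this position. Nothing measured accounts for this result. Going by these compounds, whether an amine or a nitrile on this carbon would also stay within the scatter remains open. So does whether trifluoromethyl would read the same on other carbons of the aromatic ring.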